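Swapping the aryl group on the hydrazone carbon

The source may hold more compounds than are shown below. What is called first, only, known or untested is meant among the compounds shown, and "the series" means these compounds.

Two hydrazones of the shared core have been measured. In an assay on liver (Sus scrofa) for inhibition of glucose-6-phosphatase catalytic subunit 1 (Homo sapiens), using microsomes (a higher number here means a weaker inhibitor, a lower number a stronger inhibitor), compound 1 `Oc1ccc(/C=N/N(Cc2ccccc2)Cc2ccccc2)cc1` gives 2400 nM. Compound 2 `Clc1cc(Cl)cc(/C=N/N(Cc2ccccc2)Cc2ccccc2)c1` reaches only the limit of this assay, > 100000 nM, which is a limit and not a number (the limit of > 100000 nM in this assay, at which 1 of the 2 values shown sits). For the measured compounds named here, the one measured step, an at least 41-fold higher number from compound 1 to compound 2 (1.61 log units; beyond the scatter), is therefore an at-least statement rather than a fixed size. Compound 2 thus stands at the weak end of what has been seen, with no number of its own.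

Compound 3 `C(=N/N(Cc1ccccc1)Cc1ccccc1)\c1ccco1` differs from compound 2 in one place: furan-2-yl in place of 3,5-dichlorophenyl on a carbon with a double bond to nitrogen. Going by the values given here, the only step that bears on this change is the one in which 3,5-dichlorophenyl replaced 4-hydroxyphenyl, and it was large, an at least 41-fold higher number from compound 1 to compound 2 (1.61 log units; beyond the scatter). That step shows that what sits on this carbon can move the number a long way, but it says nothing about where a furan-2-yl falls. The step is expected to be toward a lower number, an at least 2.5-fold lower number from compound 2 to compound 3 (0.39 log units; beyond the scatter), with wide uncertainty. Compound 3 is expected to give about 40000 nM, between 5000 nM and 200000 nM.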

Compound 3, half-maximal inhibitory concentration: 1100 nM
The estimate for compound 3 lay 36-fold (1.56 log units) above the measured number; the whole stated range lies above it.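

In this assay, the group on the carbon with a double bond to nitrogen now proves decisive in both directions, with furan-2-yl in place of 3,5-dichlorophenyl giving an at least 90-fold lower number from compound 2 to compound 3 (1.95 log units; beyond the scatter). That step has only a lower bound on its size, since the value of compound 2 is a limit of the assay and not a number: the limit of > 100000 nM in this assay, at which 1 of the 3 values shown sits. The other new step, a 2.2-fold lower number from compound 1 to compound 3 (0.34 log units; beyond the scatter), is modest but beyond the scatter, and it shows that the hydroxyl of the 4-hydroxyphenyl group is not required for a low number at this position, as the furan-2-yl group carries no hydrogen-bond donor and still gives the lowest number of the three compounds.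

The compounds shown leave open whether the large difference between compound 2 and compound 3 follows the two chlorine atoms, the ring size or the ring oxygen, a question that an unsubstituted phenyl or a thiophen-2-yl on this carbon would help to separate. They also leave open how much the two benzyl groups on the other nitrogen contribute, as these stay the same throughout.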